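The source may hold more compounds than are shown below. What is called first, only, known or untested is meant among the compounds shown, and "the series" means these compounds.

Within the data shown here, compound 1 `CC(C)CC1n2cncc2CN(CC2CC2)S1(=O)=O` is the only compound of the pair with a full number: in an assay on cells for inhibition of cytochrome P450 11B2, mitochondrial (Homo sapiens) (on this read-out lower numbers stand for stronger inhibition and higher numbers for weaker inhibition), compound 1 gives 758 nM. Compound 2 `CC(C)CC1n2cncc2CN(C2CC2)S1(=O)=O` is recorded only as a limit of the assay, > 1000 nM in this assay. Among the measured compounds shown here, the one measured step, an at least 1.3-fold higher number from compound 1 to compound 2 (0.12 log units; that floor lies within the scatter), is thus not a measured size but a floor, and it rests on (the limit of > 1000 nM in this assay, at which 1 of the 2 values shown sits).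

Compound 3 `CC(C)CC1n2cncc2CN(Cc2ccc(F)cc2)S1(=O)=O` is the next member: 4-fluorophenyl in place of cyclopropyl on a saturated chain carbon bound to a sulfonamide nitrogen in a ring. For the measured compounds named here, the only measured step touches the same nitrogen, but it shortened the group rather than enlarging it, and it reached only a limit; nothing measured speaks to a fluorophenyl ring at this place. From compound 1 a modest change in either direction is therefore plausible, and the expectation for the step from compound 1 to compound 3 is a 1.5-fold lower number from compound 1 to compound 3 (0.18 log units; within the scatter), within the scatter. The estimate for compound 3 in this assay is 500 nM, expected to lie between 120 nM and 2000 nM.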

Compound 3, half-maximal inhibitory concentration: 2.5 nM
Compound 3: the middle estimate sits 200-fold (2.30 log units) above what was measured, outside the stated range (below it).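

On the saturated chain carbon bound to a sulfonamide nitrogen in a ring, a 300-fold lower number from compound 1 to compound 3 (2.48 log units; beyond the scatter) shows that this place can carry a large change in this assay, which the earlier pair could not show. Compound 2 stands only as a limit, > 1000 nM, so that pair gave no measured size for any change here. Nothing shown bears on what in the 4-fluorophenyl group accounts for the step.

On these data alone, whether the step needs the fluorine or only the aromatic ring stays open, and a plain phenyl group would separate the two. A longer chain carrying the 4-fluorophenyl group, or an amine in its place, would show how far the gain extends beyond this single compound.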